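The compounds below may be only part of what the source reports. "The series", "measured", "known", "first", "only" and "open" are said of these compounds alone.

Measured so far:
compound 1 `Cc1cc(=O)n(-c2ccccc2C(F)(F)F)nc1C(=O)Nc1ccc(Oc2ncnc3ccsc23)cc1`: 8850 nM
compound 2 `Cc1ccc(-n2nc(C(=O)Nc3ccc(Oc4ncnc5ccsc45)cc3)c(C)cc2=O)c(C)c1`: 16400 nM
compound 3 `Cc1cc(=O)n(-c2ccccc2C(F)(F)F)nc1C(=O)Nc1ccc(Oc2ncnc3ccsc23)c(F)c1`: 4680 nM

In a functional assay on A549 cells (Homo sapiens) for cytotoxicity, read by MTT assay, with a stated time of 72 h (a higher number here means a weaker inhibitor, a lower number a stronger inhibitor), compound 1 gives 8850 nM. The other two numbers in this assay differ from it only within the scatter: a 1.9-fold higher number from compound 1 to compound 2 (0.27 log units; within the scatter) and a 1.9-fold lower number from compound 1 to compound 3 (0.28 log units; within the scatter). So the three measured compounds are not separated from one another in this assay.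

Compound 4 `Cc1cc(=O)n(-c2ccccc2C(F)(F)F)nc1C(=O)Nc1ccc(Oc2ncnc3sccc23)cc1` differs from compound 1 by a group of 9 heavy atoms (6 carbon, 2 nitrogen, 1 sulfur; one five-membered aromatic ring with 1 hetero atom, one six-membered aromatic ring with 2 hetero atoms) in place of a group of 9 heavy atoms (6 carbon, 2 nitrogen, 1 sulfur; one five-membered aromatic ring with 1 hetero atom, one six-membered aromatic ring with 2 hetero atoms), on an oxygen on an aromatic ring. Neither measured step touches this part of the molecule: the step from compound 1 to compound 2 changes the group on the aromatic nitrogen, the step from compound 1 to compound 3 changes a substituent on the central aromatic ring, and both stay within the scatter. There is thus no measured step that bears on the change made in compound 4, and the series has so far shown no step beyond the scatter at all.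

For compound 4 the expected step in this assay is therefore no change at the digits printed from compound 1 to compound 4 (within the scatter), none beyond the scatter. The estimate for compound 4 is 8850 nM, with a range from 3000 nM to 26000 nM.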

Compound 4, half-maximal inhibitory concentration: 19900 nM
Compound 4: middle estimate off by 2.2-fold (0.35 log units), on the low side; the measured number falls inside the stated range.
By their numbers in this assay, from the lowest: compounds 3, 1, 2 and 4 (each within the scatter of the next, the first and the last beyond it).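

In this assay, among the compounds shown here, rearranging the group on the oxygen gives a 2.2-fold higher number from compound 1 to compound 4 (0.35 log units; beyond the scatter), a modest change but the only step so far that lies beyond the scatter. This position is therefore sensitive to how the same atoms are joined: the leaving and entering groups match in heavy atoms, ring types, hydrogen-bond donors and acceptors and net charge, so none of these counts separates compound 1 from compound 4. No measurement available here accounts for the difference between the two arrangements.

Open, on these data alone, is whether a simple phenyl, or the same group bearing an amine, would keep the number near that of compound 1 or shift it further. Also open, as far as these compounds go, is whether the same rearrangement gives a similar step with the 2,4-dimethylphenyl group or the fluoro substituent present.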